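Ester in Place of Alcohol on a Macrocyclic Lactone

The source may hold more compounds than are shown below. What is called first, only, known or untested is meant among the compounds shown, and "the series" means these compounds.

Two lactones were tested in a functional assay on Ca9-22 cells (Homo sapiens) for cytotoxicity, read by MTT assay; on this read-out higher numbers stand for weaker inhibition and lower numbers for stronger inhibition. Compound 1, `C=C1C(=O)O[C@H]2C/C(C)=C/[C@@H](O)C/C(C)=C/CC/C(C)=C/C[C@H]12`, gives 3.2 ug/mL. Compound 2, `C=C1C(=O)O[C@H]2/C=C(\C)CC/C=C(\CO)CC/C=C(\C)CC[C@@H]12`, reached only the limit of the assay, > 5 ug/mL, so no exact number is known for it. On the numbers shown, compound 2 therefore stands at the weak end of the pair, since the limit of > 5 ug/mL in this assay, at which 1 of the 2 values shown sits, marks where its value sits.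

Compound 3, `C=C1C(=O)O[C@H]2/C=C(\C)CC/C=C(\C(=O)OC)CC/C=C(\C)CC[C@@H]12`, differs from compound 2 in one place: methoxycarbonyl in place of hydroxymethyl on a double-bonded ring carbon. Among the measured compounds shown here, no step between measured compounds is available here, so the size of this change can only be expected, not read from data. The step from compound 2 to compound 3 is estimated at a step that the limit leaves unreadable from compound 2 to compound 3, that is, no change beyond the usual scatter. Compound 3 is therefore expected to give about 6 ug/mL in this assay, with a likely range from 2 ug/mL to 20 ug/mL, and a fair chance that only a limit is reported again.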

Compound 3, half-maximal inhibitory concentration: 1.7 ug/mL
Beside the measured number, compound 3's estimate is 3.5-fold (0.55 log units) above it; measured number below the stated range.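

In this assay, the swap at this double-bonded ring carbon gives an at least 2.9-fold lower number from compound 2 to compound 3 (0.46 log units; beyond the scatter), so what this position carries clearly matters for the read-out. The incoming methoxycarbonyl has no hydrogen-bond donor, which shows that the hydroxymethyl group and its donor are not needed for cytotoxicity on this core. The value for compound 2 is a limit rather than an exact number, so the step gives only a minimum size: the limit of > 5 ug/mL in this assay, at which 1 of the 3 values shown sits.

The compounds shown cannot separate the effect of losing the hydroxymethyl group from that of gaining the methoxycarbonyl group, and they do not explain the step. From the compounds shown here alone, it also remains open how a carboxylic acid, a primary amide or the longer ethoxycarbonyl group would behave on this same carbon.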